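From 2-phenylethenyl to 1H-indol-3-yl on the shared core

The source may hold more compounds than are shown below. What is called first, only, known or untested is meant among the compounds shown, and "the series" means these compounds.

In a functional assay on ECa-109 cells (Homo sapiens) for cytotoxicity, read by MTT assay, with a stated time of 72 h (on this read-out higher numbers stand for weaker inhibition and lower numbers for stronger inhibition), compound 1 `O=C1C(=Cc2ccc(Br)cc2)C(=O)N(c2ccc(Cl)cc2)N1c1ccc(Cl)cc1` gives 12300 nM and compound 2 `O=C1C(=C/C=C/c2ccccc2)C(=O)N(c2ccc(Cl)cc2)N1c1ccc(Cl)cc1` gives 9900 nM, so compound 2 stands level with compound 1. Compound 3 `O=C1C(=Cc2c[nH]c3ccccc23)C(=O)N(c2ccc(Cl)cc2)N1c1ccc(Cl)cc1` carries 1H-indol-3-yl in place of 2-phenylethenyl on a double-bonded chain carbon bound to a double-bonded ring carbon. Among the measured compounds shown here, the only measured step at this place is a 1.2-fold lower number from compound 1 to compound 2 (0.09 log units; within the scatter), a single and thin precedent. No shift beyond the scatter is therefore expected in this assay, and no direction is favoured. The expected step is a 1.1-fold lower number from compound 2 to compound 3 (0.04 log units; within the scatter). The estimate for compound 3 is 9000 nM, with an expected range of 3000 nM to 25000 nM.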

Compound 3, half-maximal inhibitory concentration: 23400 nM
Compound 3: the middle estimate sits 2.6-fold (0.41 log units) below what was measured; low and high end bracket the measured number.
By their numbers in this assay, from the lowest: compounds 2, 1 and 3 (each within the scatter of the next, the first and the last beyond it).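

In this assay, among the compounds shown here, this place is no longer silent: a 2.4-fold higher number from compound 2 to compound 3 (0.37 log units; beyond the scatter) is the first step here beyond the scatter, which puts 1H-indol-3-yl on the weaker side of 2-phenylethenyl. Against 4-bromophenyl, however, a 1.9-fold higher number from compound 1 to compound 3 (0.28 log units; within the scatter) stays within the scatter, so the group's effect depends on the comparison. No available evidence bears on the reason for this shift.

Still open, on these data alone, is whether 1-methyl-1H-indol-3-yl would keep the number of compound 3, which would test the ring hydrogen-bond donor. An amine or a carboxylic acid at this place also remains to be placed in the series.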